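Quinazoline-piperazine series: pyridinyl capping of the piperazine

A few compounds are considered here, and "the series" means these few. Any claim that something is new, unique, unknown or untested is made for them only; others in the source may bear on it.

Measured so far:
- compound 1, `COc1ccc(-c2nc(N3CCNCC3)nc3ccccc23)c(OC)c1`, 50 ug/mL
- compound 2, `c1ccc2c(c1)ccn2-c1nc(N2CCNCC2)nc2ccccc12`, 14.1 ug/mL
- compound 3, `COc1cc(OC)c(-c2nc(N3CCN(C)CC3)nc3ccccc23)c(OC)c1`, 50 ug/mL

In a functional assay on MCF7 cells (Homo sapiens) for antiproliferative activity, read by MTT assay (a higher number here means a weaker inhibitor, a lower number a stronger inhibitor), compound 2 gives 14.1 ug/mL, the lowest of the three numbers. Its nearest neighbour is compound 1, whose value lies beyond the scatter above it, and compound 3 stands at the same distance, also beyond the scatter. Compound 1 and compound 3 themselves give equal numbers, so no order can be read between them, and they differ in more than one place, so nothing can be said about the bare piperazine against its methylated counterpart on its own.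

Compound 4, `c1ccc(N2CCN(c3nc(-n4ccc5ccccc54)c4ccccc4n3)CC2)nc1`, keeps the indole-bearing core of compound 2 and changes it in one place: pyridin-2-yl in place of hydrogen on an amine nitrogen in a ring. Among the measured compounds shown here, no step among the measured compounds covers a substitution of this kind, so the direction rests only on compound 2 as starting point. In this assay a modest step downward from compound 2 is expected, of about a 1.8-fold lower number from compound 2 to compound 4 (0.25 log units; within the scatter), though a value within the scatter of compound 2 would not surprise. Compound 4 is therefore estimated at 8 ug/mL, with a range from 2 ug/mL to 30 ug/mL.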

Compound 4, half-maximal inhibitory concentration: 50 ug/mL
The estimate for compound 4 lay 6.3-fold (0.80 log units) below the measured number; measured number outside the range, above it.
By their numbers in this assay, from the lowest: compound 2; then compounds 1, 3 and 4 (each within the scatter of the next).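

In this assay, the amine nitrogen in the ring of compound 2 now has a one-place change read against it: pyridin-2-yl in place of hydrogen gives a 3.5-fold higher number from compound 2 to compound 4 (0.55 log units; beyond the scatter), so this position does not take this group without a loss. Among the compounds shown, the lowest number therefore goes with the hydrogen at this nitrogen, although this rests on a single step with a single group. No measurement at hand accounts for the step.

Going by these compounds, it remains open whether the loss belongs to pyridin-2-yl itself or would follow any replacement of that hydrogen. A phenyl, benzyl or acetyl group on the same nitrogen, with the rest of compound 2 unchanged, would separate these two readings.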